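The source may hold more compounds than are shown below. What is called first, only, known or untested is meant among the compounds shown, and "the series" means these compounds.

Two close cores make up the pair on record: compound 1 `Cc1c(C)c2ccc(OCC3CCN(Cc4cccc(CO)c4)CC3)cc2oc1=O` and compound 2 `Cc1cc(=O)oc2cc(OCC3CCN(Cc4ccc(CO)cc4)CC3)ccc12`, which differ both in the core and in the hydroxymethyl placement on the benzyl group. In an assay for inhibition of Amine oxidase [flavin-containing] B (Homo sapiens), read by fluorescence, using microsomes, with a stated time of 30 min (on this read-out higher numbers stand for weaker inhibition and lower numbers for stronger inhibition), compound 1 gives 76 nM. Compound 2 stands at the higher of the two numbers recorded, giving 600 nM in this assay; because the two differ in more than one place, their gap is noted without being assigned to any single change. Compound 3 `Cc1cc(=O)oc2cc(OCC3CCN(Cc4cccc(CO)c4)CC3)ccc12` keeps the core of compound 2 and alters only the benzyl substituent: 3-(hydroxymethyl)phenyl in place of 4-(hydroxymethyl)phenyl on a saturated chain carbon bound to an amine nitrogen in a ring. Going by the values given here, no measured step isolates this change. Compound 1 carries the same 3-(hydroxymethyl)phenyl arrangement and gives 76 nM in this assay. On that basis a moderate move toward a lower number is expected for compound 3, a 2.7-fold lower number from compound 2 to compound 3 (0.44 log units; beyond the scatter), with wide uncertainty. The estimate for compound 3 in this assay is 220 nM, within 60 nM to 800 nM.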

Compound 3, half-maximal inhibitory concentration: 480 nM
Compound 3: middle estimate off by 2.2-fold (0.34 log units), on the low side, within the range that was stated.
By their numbers in this assay, from the lowest: compound 1; then compounds 3 and 2 (each within the scatter of the next).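

On the core of compound 2, the benzyl placement can now be read on its own: 3-(hydroxymethyl)phenyl in place of 4-(hydroxymethyl)phenyl gives a 1.3-fold lower number from compound 2 to compound 3 (0.10 log units; within the scatter), so this assay does not separate the two placements on this core. With 3-(hydroxymethyl)phenyl held constant, hydrogen in place of methyl on an aromatic carbon gives a 6.3-fold higher number from compound 1 to compound 3 (0.80 log units; beyond the scatter), so this core change, not the benzyl placement, is the step that lies beyond the scatter. No supporting data bear on the reason for either result.

Whether the placement is equally silent on the core of compound 1 remains open, as only 3-(hydroxymethyl)phenyl is shown on that core. Also open, going by these compounds, is how a carboxylic acid or an amine in place of the hydroxymethyl, or an ethyl group in place of that methyl, would read.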